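This account rests on a few compounds, and the source may have more. Where it says the series, first, only, none or still open, it means among the compounds named here.

Measured compounds:
Compound 1, `Oc1ccc(/C=N/NC(=S)Nc2ccccc2)cc1`: in an assay for inhibition of ribonucleoside-diphosphate reductase RR1 (Homo sapiens), with a stated time of 30 min (on this read-out lower numbers stand for stronger inhibition and higher numbers for weaker inhibition), compound 1 gives 242000 nM.
Compound 2, `Oc1ccc(/C=N/NC(=S)Nc2ccc(Cl)cc2)cc1`: compound 2 gives 287000 nM.
Compound 3, `Oc1ccc(/C=N/NC(=S)Nc2ccccc2Cl)cc1`: compound 3 gives 46800 nM.

Of the three numbers, compound 2 stands at the highest. Its nearest neighbour is compound 1, and the gap between them, a 1.2-fold higher number from compound 1 to compound 2 (0.07 log units; within the scatter), lies within the scatter, so the two are not told apart. Compound 3 is clearly lower, since a 5.2-fold lower number from compound 1 to compound 3 (0.71 log units; beyond the scatter) lies beyond the scatter.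

Compound 4, `Cc1ccc(NC(=S)N/N=C/c2ccc(O)cc2)cc1`, has not yet been measured. It differs from compound 2 in one place: methyl in place of chloro on an aromatic carbon.

Going by the values given here, only one measured step bears on this position. Going from compound 1 to compound 2 put a chloro at the same position, and a 1.2-fold higher number from compound 1 to compound 2 (0.07 log units; within the scatter) was within the scatter, so that site appears to take a small group without the number moving much. Among the compounds with values here, no step shows a methyl anywhere, so there is no direct precedent for the swap itself. On this slim basis, the step of a 1.1-fold lower number from compound 2 to compound 4 (0.06 log units; within the scatter) is expected to stay within the scatter, in no particular direction. Compound 4 is therefore estimated at 250000 nM, with a range from 100000 nM to 600000 nM.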

Compound 4, half-maximal inhibitory concentration: 14200 nM
Compound 4: middle estimate off by 18-fold (1.25 log units), on the high side, outside the stated range (below it).
By their numbers in this assay, from the lowest: compound 4; then compound 3; then compounds 1 and 2 (each within the scatter of the next).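

In this assay, this place on the ring turns out to be far from indifferent to what sits there: methyl in place of hydrogen gives a 17-fold lower number from compound 1 to compound 4 (1.23 log units; beyond the scatter) and methyl in place of chloro gives a 20-fold lower number from compound 2 to compound 4 (1.31 log units; beyond the scatter). The earlier chloro step could not show this, since it only suggested that the site accepts a small group with little change, and that reading holds for chloro but not for methyl. Chloro and methyl each count one heavy atom, no ring and no hydrogen-bond donors or acceptors, so these counts do not separate two groups that give such different numbers here.

Nothing available explains why methyl and chloro part so widely at this place. On these data alone, it remains open whether the lower number belongs to methyl alone or also extends to a longer chain such as ethyl, or to a methoxy group or an amine at this place, and whether a methyl at the place where compound 3 carries its chloro would also move the number.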